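The compounds below may be only part of what the source reports. "The series", "measured", "known", "first", "only" and "open" are said of these compounds alone.

Compound 2 `O=C(Nc1cccc(-c2nc3ccccc3s2)c1)c1ccnc(Cl)c1` carries a 2-chloropyridin-4-yl group on the carbonyl carbon of its amide. In an ADME assay on HepG2 cells (Homo sapiens) for inhibition, with a stated time of 72 h (a higher number here means that more compound is needed for the effect, a lower number that less compound is needed), compound 2 gives only a limit, > 25000 nM. Its close relative compound 1 `O=C(Nc1cccc(-c2nc3ccccc3s2)c1)c1cccnc1Cl` likewise gives only a limit in this assay, > 25000 nM. The step that the two limits leave unreadable from compound 1 to compound 2 therefore cannot be sized, because both values sit at the limit of > 25000 nM in this assay, at which 2 of the 2 values shown sit. Compound 3 `O=C(Nc1cccc(-c2nc3ccccc3s2)c1)c1ccncc1Cl` differs from compound 2 by 3-chloropyridin-4-yl in place of 2-chloropyridin-4-yl on a carbonyl carbon. For the measured compounds named here, the single measured step concerns a change of the same group at the same place and gave no readable size, so no direction can be drawn from it; neither measured compound produced a number in this assay. On that basis compound 3 is expected to remain at the limit as well, with an estimated value of 40000 nM and a range from 15000 nM to 150000 nM. The expected step that the limit leaves unreadable from compound 2 to compound 3 is estimated to be no change beyond the scatter.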

Compound 3, half-maximal effective concentration: > 25000 nM
Compound 3: no number, only a limit; the forecaster's own chance of this, stated with the estimate: 85%; the middle value is on the limit's open side.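

Compound 3, like compound 1 and compound 2, gives only a limit in this assay, so no step among these three compounds can be read: the limit of > 25000 nM in this assay, at which 3 of the 3 values shown sit.

The compounds shown leave open what concentration any of the three needs for the effect, and whether the 2-chloropyridin-3-yl, 2-chloropyridin-4-yl and 3-chloropyridin-4-yl groups differ at all in this assay.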